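Para-Substituent Swap on the Triazolylphenyl Ring: Amino Analogue

The source may hold more compounds than are shown below. What is called first, only, known or untested is meant among the compounds shown, and "the series" means these compounds.

Working notes on the cytotoxicity series. The shared core carries a phenyl ring on the triazole whose para substituent is the only point of variation. Compound 1 `Cc1ccc(-n2cc(CNC(=O)c3c[nH]c(-c4ccccc4)n3)nn2)cc1` gives 409000 nM in an ADME assay on Vero cells (Chlorocebus sabaeus) for cytotoxicity, read by MTT assay, with a stated time of 72 h; a lower number here means a stronger inhibitor, a higher number a weaker inhibitor. Compound 2 `COc1ccc(-n2cc(CNC(=O)c3c[nH]c(-c4ccccc4)n3)nn2)cc1` gives 388000 nM in this assay, and compound 3 `O=C(NCc1cn(-c2ccc(O)cc2)nn1)c1c[nH]c(-c2ccccc2)n1` gives 281000 nM. Compound 2 sits second highest of the three numbers, closest to compound 1 and furthest from compound 3, with every gap inside the scatter: a 1.1-fold lower number from compound 1 to compound 2 (0.02 log units; within the scatter), a 1.5-fold lower number from compound 1 to compound 3 (0.16 log units; within the scatter), a 1.4-fold lower number from compound 2 to compound 3 (0.14 log units; within the scatter).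

Compound 4 `Nc1ccc(-n2cc(CNC(=O)c3c[nH]c(-c4ccccc4)n3)nn2)cc1` is not yet measured. Its change from compound 2 reads: amino in place of methoxy on an aromatic carbon. The measured steps that bear on it are the other para replacements on the same ring, methyl to methoxy, methyl to hydroxy and methoxy to hydroxy, and none of them moved the number beyond the scatter. Since a hydrogen-bond donor entering at this position, in compound 3, left the number essentially unchanged, the step of a 1.1-fold lower number from compound 2 to compound 4 (0.04 log units; within the scatter) is expected to be of no size beyond the scatter, in no firm direction. The estimate for compound 4 is 350000 nM, with a range from 200000 nM to 600000 nM.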

Compound 4, half-maximal inhibitory concentration: 237000 nM
Compound 4: middle estimate off by 1.5-fold (0.17 log units), on the high side; low and high end bracket the measured number.
By their numbers in this assay, from the lowest: compounds 4, 3, 2 and 1 (each within the scatter of the next).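

Amino is a fourth group on this aromatic carbon that stays within the scatter of all the others in this assay, whether it replaces methoxy (a 1.6-fold lower number from compound 2 to compound 4 (0.21 log units; within the scatter)), hydroxy (a 1.2-fold lower number from compound 3 to compound 4 (0.07 log units; within the scatter)) or methyl (a 1.7-fold lower number from compound 1 to compound 4 (0.24 log units; within the scatter)). Even the largest of these steps, the one that starts from the methyl group of compound 1, does not leave the scatter, so the four compounds cannot be separated by their numbers. Nothing measured here offers an explanation for these numbers.

Going by these compounds, what stays open is whether any group on this carbon can separate from these four, for instance a carboxylic acid, a trifluoromethyl group, a chlorine atom or a longer chain such as butoxy. On these data alone, whether the same flat reading would hold on a core altered elsewhere also remains open, as all four compounds share one core and differ only in this single substituent.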